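Diethylamino amide: expected step from compound 3 to compound 4

A few compounds are considered here, and "the series" means these few. Any claim that something is new, unique, unknown or untested is made for them only; others in the source may bear on it.

The three measured compounds share one core and differ only in the group on the amide nitrogen: compound 1 `CC(C)NC(=O)c1cc(-c2ccc(Cl)cc2Cl)n[nH]1`, compound 2 `CC(C)(C)NC(=O)c1cc(-c2ccc(Cl)cc2Cl)n[nH]1` and compound 3 `COCCNC(=O)c1cc(-c2ccc(Cl)cc2Cl)n[nH]1`. In an assay on isolated protein for inhibition of alkaline phosphatase, tissue-nonspecific isozyme (Homo sapiens) (on this read-out higher numbers stand for weaker inhibition and lower numbers for stronger inhibition), compound 1 gives 51 nM, compound 2 gives 398 nM and compound 3 gives 46 nM. Compound 3 carries the lowest number of the three, but the step of a 1.1-fold lower number from compound 1 to compound 3 (0.04 log units; within the scatter) is within the scatter, so compound 1 and compound 3 are not distinguished. Compound 2 stands apart, with a 7.8-fold higher number from compound 1 to compound 2 (0.89 log units; beyond the scatter) and an 8.7-fold lower number from compound 2 to compound 3 (0.94 log units; beyond the scatter).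

Compound 4 `CCN(CC)C(=O)c1cc(-c2ccc(Cl)cc2Cl)n[nH]1` carries diethylamino in place of (2-methoxyethyl)amino on a carbonyl carbon. For the measured compounds named here, no measured step removes the hydrogen from the amide nitrogen; the measured steps only exchange chains on a secondary amide. Of those, a 1.1-fold lower number from compound 1 to compound 3 (0.04 log units; within the scatter) shows a chain exchange without cost, whereas a 7.8-fold higher number from compound 1 to compound 2 (0.89 log units; beyond the scatter) shows that one added methyl on the saturated carbon bound to the amide nitrogen costs a modest step. Diethylamino puts two chains on the nitrogen itself and carries no hydrogen-bond donor, a change the measured steps do not cover. The expectation is a weakening step of about the size seen for compound 2, estimated as an 8.7-fold higher number from compound 3 to compound 4 (0.94 log units; beyond the scatter). Compound 4 is expected at 400 nM, with a range of 80 nM to 2500 nM.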

Compound 4, half-maximal inhibitory concentration: 285 nM
Beside the measured number, compound 4's estimate is 1.4-fold (0.15 log units) above it; the measured number falls inside the stated range.
By their numbers in this assay, from the lowest: compounds 3 and 1 (each within the scatter of the next); then compounds 4 and 2 (each within the scatter of the next).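

In this assay, diethylamino in place of (2-methoxyethyl)amino on the carbonyl carbon gives a 6.2-fold higher number from compound 3 to compound 4 (0.79 log units; beyond the scatter) and diethylamino in place of isopropylamino gives a 5.6-fold higher number from compound 1 to compound 4 (0.75 log units; beyond the scatter) as the other clear step, so the first amide in the series without the amide hydrogen falls away from the level shared by compound 1 and compound 3. The comparison with the (tert-butyl)amino amide gives a 1.4-fold lower number from compound 2 to compound 4 (0.15 log units; within the scatter) and leaves those two groups undistinguished, so two different changes at this place arrive at the same level, and the exchange from compound 3 also removes the ether oxygen, which leaves the step unassigned between the two losses counted for it. No measurement shown gives a reason for these steps.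

Open, on these data alone, is whether the amide hydrogen alone carries the step, which N-methyl-(2-methoxyethyl)amino on the carbonyl carbon would test directly against compound 3. Also open, as far as these compounds go, is how far the lower level extends along the chain, with 3-methoxypropylamino as one test, and whether ring amines such as pyrrolidine or morpholine behave like diethylamino.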